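Swapping the aryl group on the piperazine of compound 2

The source may report more compounds than this note shows. Statements on the series, on what has been measured and on what is new or still open speak of the compounds shown alone.

The shared core, seen in compound 1 `COc1cc2ncnc(N3CCC(CN4CCN(c5ccccc5OC)CC4)C3)c2cc1OC`, carries a piperazine whose nitrogen bears an aromatic ring. In an assay on membranes from CHO-K1 cells for displacement of a labelled ligand from 5-hydroxytryptamine receptor 7 (Homo sapiens), read by scintillation counting (on this read-out higher numbers stand for weaker inhibition and lower numbers for stronger inhibition), compound 1 gives 56.2 nM. Compound 2 `COc1cc2ncnc(N3CCC(CN4CCN(c5ccc(O)cc5)CC4)C3)c2cc1OC` differs only in that ring. In this assay compound 2 gives > 1000 nM, which is a limit of the assay rather than a number. So the step of an at least 17-fold higher number from compound 1 to compound 2 (1.25 log units; beyond the scatter) is known only as a lower bound, set by the limit of > 1000 nM in this assay, at which 1 of the 2 values shown sits. Compound 3 `COc1cc2ncnc(N3CCC(CN4CCN(c5cccc(Cl)c5Cl)CC4)C3)c2cc1OC` changes that same position again: 2,3-dichlorophenyl in place of 4-hydroxyphenyl on an amine nitrogen in a ring. Going by the values given here, the one measured step shows that replacing 2-methoxyphenyl by 4-hydroxyphenyl weakened binding strongly; compound 3 removes the 4-hydroxyphenyl and brings in a second substituted aryl, so the expectation is a large step back, with a markedly lower number than compound 2, near where compound 1 stands. Compound 3 is therefore estimated at 40 nM, within 10 nM to 200 nM, an expected step of an at least 25-fold lower number from compound 2 to compound 3 (1.39 log units; beyond the scatter).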

Compound 3, inhibition constant: 347 nM
Estimate against measurement, compound 3: 8.7-fold (0.94 log units) below; the measured number lies above the stated range.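

In this assay, the aryl ring on the piperazine can regain part of the binding lost with 4-hydroxyphenyl, and 2,3-dichlorophenyl gives an at least 2.8-fold lower number from compound 2 to compound 3 (0.45 log units; beyond the scatter). The limit belongs to compound 2, so this step is only a lower bound: the limit of > 1000 nM in this assay, at which 1 of the 3 values shown sits.

Even so, 2,3-dichlorophenyl does not return binding to the level seen with 2-methoxyphenyl, as the data show a 6.2-fold higher number from compound 1 to compound 3 (0.79 log units; beyond the scatter), and this leaves compound 1 with the strongest binding of the three.

The three aryl groups differ in both the kind and the placing of their substituents, so these compounds cannot show which of those differences matters most. As far as these compounds go, it remains open where an unsubstituted phenyl ring, or a phenyl ring carrying a single chlorine, would stand against these three.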